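This account rests on a few compounds, and the source may have more. Where it says the series, first, only, none or still open, it means among the compounds named here.

Measured so far in a functional assay on HeLa cells (Homo sapiens) for cytotoxicity, with a stated time of 72 h; on this read-out higher numbers stand for weaker inhibition and lower numbers for stronger inhibition:
- compound 1 `O=Cc1c(-c2ccc(Br)cc2)nc2sc(Cc3ccc(Cl)cc3)nn12` gives 4200 nM
- compound 2 `O=Cc1c(-c2ccc(Cl)cc2Cl)nc2sc(Cc3ccc(Cl)cc3)nn12` gives 64000 nM

Compound 2 stands at the highest of the two numbers, meaning the weaker of the two. Among the measured compounds shown here, the only measured step is a 15-fold higher number from compound 1 to compound 2 (1.18 log units; beyond the scatter), which came with 2,4-dichlorophenyl in place of 4-bromophenyl on an aromatic carbon. That step concerns the aryl group and says nothing about the other substituent on the shared core.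

Compound 3 `N#CSc1c(-c2ccc(Cl)cc2Cl)nc2sc(Cc3ccc(Cl)cc3)nn12` has not yet been measured. It differs from compound 2 in one place: cyanosulfanyl in place of formyl on an aromatic carbon. For the measured compounds named here, no measured pair in this set changes that group, so no step bears on the present change, and there is no basis for expecting a shift in either direction beyond the scatter. The expectation therefore rests on compound 2 alone, with a wide margin for the unknown. Compound 3 is estimated at 64000 nM, with a range from 13000 nM to 300000 nM. This estimate means an expected no change at the digits printed from compound 2 to compound 3 (within the scatter), a step taken as no change beyond the scatter, though a high number of this size may also be reported only as a limit.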

Compound 3, half-maximal inhibitory concentration: 18000 nM
Compound 3: the middle estimate sits 3.6-fold (0.55 log units) above what was measured; the measured number falls inside the stated range.
By their numbers in this assay, from the lowest: compound 1; then compound 3; then compound 2.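

In this assay, the carbon that bears formyl in compound 2 turns out to be a place where a change registers: cyanosulfanyl in place of formyl gives a 3.6-fold lower number from compound 2 to compound 3 (0.55 log units; beyond the scatter). Among the compounds shown here, until now, the only step concerned the aryl group, so this is the first sign that the number also responds to the other substituent on the shared core, and that formyl is not needed for a measurable effect on HeLa cells, since the lower number comes with formyl gone. No measurement here speaks to the reason for this shift, which therefore stands only as an observation.

As far as these compounds go, it remains open whether the lower number is specific to cyanosulfanyl or would also appear with other groups at this carbon, such as an amine, a carboxylic acid or a longer chain. From the compounds shown here alone, it is also open whether the same exchange would give a step of similar size and direction with a 4-bromophenyl group in place of the 2,4-dichlorophenyl group, since a step at one place need not carry over when another part of the compound differs.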